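Aryl exchange on the shared core: notes towards compound 3

A few compounds are considered here, and "the series" means these few. Any claim that something is new, unique, unknown or untested is made for them only; others in the source may bear on it.

Measured so far in a functional assay on LN-229 cells (Homo sapiens) for antiproliferative activity, with a stated time of 72 h (on this read-out higher numbers stand for weaker inhibition and lower numbers for stronger inhibition), for two compounds
- compound 1 `Nc1ncnn2c([C@@H]3O[C@H](CO)[C@@H](O)[C@H]3O)cc(-c3ccc(F)cc3F)c12` gives 43500 nM in this series
- compound 2 `COc1ccc(-c2cc([C@@H]3O[C@H](CO)[C@@H](O)[C@H]3O)n3ncnc(N)c23)cc1` gives 40300 nM in this series

Among the compounds with values here, compound 2 gives 40300 nM in this assay and stands level with compound 1, the only other measured compound. The next compound is compound 3 `Nc1ncnn2c([C@@H]3O[C@H](CO)[C@@H](O)[C@H]3O)cc(-c3ccccc3Cl)c12`, with 2-chlorophenyl in place of 4-methoxyphenyl on an aromatic carbon of the shared core. Within the data shown here, one measured step bears on this change: a 1.1-fold lower number from compound 1 to compound 2 (0.03 log units; within the scatter) with 4-methoxyphenyl in place of 2,4-difluorophenyl on that same carbon. Among the measured compounds shown here, no measured compound carries 2-chlorophenyl, and a single step is thin evidence. Even so, no step beyond the scatter is expected in this assay in either direction. The expected move is a 1.2-fold lower number from compound 2 to compound 3 (0.06 log units; within the scatter) on this estimate. For compound 3 the estimated value is 35000 nM with an expected range of 10000 nM to 70000 nM in this read-out.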

Compound 3, half-maximal inhibitory concentration: > 100000 nM
Compound 3 gave a limit, no number; the forecaster's own chance of this, stated with the estimate: 25%; at least 2.8-fold (0.45 log units) between middle value and limit.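

In this assay compound 3 gives > 100000 nM, which is a limit of the assay and not a number. The aromatic carbon two ring bonds from the ring nitrogen is therefore not indifferent to the aryl group it carries: 2-chlorophenyl gives an at least 2.4-fold higher number from compound 2 to compound 3 (0.39 log units; beyond the scatter) and an at least 2.2-fold higher number from compound 1 to compound 3 (0.36 log units; beyond the scatter), whereas the earlier exchange gave a 1.1-fold lower number from compound 1 to compound 2 (0.03 log units; within the scatter). The read-out gives no exact size for either new step, and one value shown stands at the end of its range: the limit of > 100000 nM in this assay, at which 1 of the 3 values shown sits.

Open, as far as these compounds go, is whether the step follows the chlorine itself or the place it holds on the phenyl ring; a 4-chlorophenyl or an unsubstituted phenyl group on the shared core would separate the two. Also open, from the compounds shown here alone, is how an amine or a carboxylic acid on that phenyl ring would read in this assay.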